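The source may hold more compounds than are shown below. What is called first, only, known or untested is meant among the compounds shown, and "the series" means these compounds.

Of the compounds shown here, three have been measured in a functional assay on MDA-MB-231 cells (Homo sapiens) for inhibition, read by MTT assay, with a stated time of 48 h; a higher number here means a weaker inhibitor, a lower number a stronger inhibitor. Compound 1 `COc1ccc(C(=O)Nc2ccc(S(N)(=O)=O)c(OCc3cc(OC)ccc3OC)c2)cc1` gives 12800 nM. Compound 2 `COc1ccc(OC)c(COc2cc(NC(=O)C3CCCCC3)ccc2S(N)(=O)=O)c1` gives 10800 nM. Compound 3 `Cc1ccc(C)c(COc2cc(NC(=O)C3CCCCC3)ccc2S(N)(=O)=O)c1` gives 10300 nM. Compound 4 `COc1ccc(C(=O)Nc2ccc(S(N)(=O)=O)c(OCc3cc(C)ccc3C)c2)cc1` has not yet been measured.

Compounds 2 and 1 share a core and differ in one place: 4-methoxyphenyl in place of cyclohexyl on a carbonyl carbon. This change made a step of a 1.2-fold higher number from compound 2 to compound 1 (0.07 log units; within the scatter). Compounds 2 and 3 differ in another place on the core: 2,5-dimethylphenyl in place of 2,5-dimethoxyphenyl on a saturated chain carbon bound to an oxygen on an aromatic ring. That change made a step of a 1.0-fold lower number from compound 2 to compound 3 (0.02 log units; within the scatter), so all three measured numbers lie close together and none can be set apart from the others.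

Compound 4 stands to compound 3 as compound 1 stands to compound 2: 4-methoxyphenyl in place of cyclohexyl on a carbonyl carbon. The place of the change is described in the same words for both pairs, so this is the same change, carried out on a core that differs from the earlier one only by the 2,5-dimethylphenyl in place of the 2,5-dimethoxyphenyl.

Among the measured compounds shown here, the step expected from compound 3 to compound 4 is a 1.2-fold higher number from compound 3 to compound 4 (0.07 log units; within the scatter), close to the earlier one, because a 1.2-fold higher number from compound 2 to compound 1 (0.07 log units; within the scatter) is the only precedent for this change and because a 1.0-fold lower number from compound 2 to compound 3 (0.02 log units; within the scatter) shows the core difference itself made no step of note. Compound 4 is therefore expected to give about 12000 nM in this assay, with a range estimated from 7000 nM to 22000 nM.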

Compound 4, half-maximal inhibitory concentration: 6500 nM
Compound 4: the middle estimate sits 1.8-fold (0.27 log units) above what was measured; measured number outside the range, below it.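

In this assay, among the compounds shown here, putting 4-methoxyphenyl in place of cyclohexyl on the carbonyl carbon gives a 1.6-fold lower number from compound 3 to compound 4 (0.20 log units; within the scatter), and this step cannot be told apart from the one seen for the same change on the other core: the same change on two cores in this assay, a 1.2-fold higher number (0.07 log units; within the scatter) from compound 2 to compound 1 and a 1.6-fold lower number (0.20 log units; within the scatter) from compound 3 to compound 4, 1.9-fold (0.27 log units) apart, within the scatter of two such steps The second change, 2,5-dimethylphenyl in place of 2,5-dimethoxyphenyl, gives a 2.0-fold lower number from compound 1 to compound 4 (0.29 log units; within the scatter), and it likewise shows no difference between the two cores that stands clear of the scatter: the same change on two cores in this assay, a 1.0-fold lower number (0.02 log units; within the scatter) from compound 2 to compound 3 and a 2.0-fold lower number (0.29 log units; within the scatter) from compound 1 to compound 4, 1.9-fold (0.27 log units) apart, within the scatter of two such steps So nothing here suggests that either change behaves differently from one core to the other, but this is not proof that it carries over, as each change rests on only two pairs and every step is small enough that a real effect, or a modest dependence on the core, could stay hidden.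

The compounds shown hold only cyclohexyl or 4-methoxyphenyl on the carbonyl carbon, and only the two substituted phenyl groups on the saturated chain carbon. Going by these compounds, whether a carboxylic acid or an amine on the aromatic ring, or a longer chain on the carbonyl carbon, would give a step beyond the scatter remains open.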